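The source may hold more compounds than are shown below. What is called first, only, known or untested is meant among the compounds shown, and "the series" means these compounds.

Compound 1 `CC(=O)N1CCC(NC(=O)c2ccncc2Nc2cc(-c3ccc4ccn(C)c4c3)c3nccnc3c2)CC1` gives 18 nM in an assay for inhibition of 6-phosphofructo-2-kinase/fructose-2,6-bisphosphatase 3 (Homo sapiens), read by ADP-Glo, with a stated time of 2 h; a lower number here means a stronger inhibitor, a higher number a weaker inhibitor.
Compound 2 `CN1CC(NC(=O)c2ccncc2Nc2cc(-c3ccc4ccn(C)c4c3)c3nccnc3c2)CCC1=O` gives 116 nM in this assay.
Compound 3 `CC(=O)N1CC(NC(=O)c2ccncc2Nc2cc(-c3ccc4ccn(C)c4c3)c3nccnc3c2)C1` gives 73 nM in this assay.

All three share the same core and differ only in the ring carried on the amide-type nitrogen. Compound 3 stands second highest of the three numbers: its step to compound 2 is within the scatter, while the step from compound 1 to compound 3 is a 4.1-fold higher number from compound 1 to compound 3 (0.61 log units; beyond the scatter), so compound 1 clearly gives the lower number.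

Compound 4 `CC(=O)N1CCC(NC(=O)c2ccncc2Nc2cc(-c3ccc4ccn(C)c4c3)c3nccnc3c2)C1` has not been measured. It differs from compound 3 in one place: 1-acetylpyrrolidin-3-yl in place of 1-acetylazetidin-3-yl on an amide-type nitrogen. Within the data shown here, the step that bears most directly on this change is the one between compound 1 and compound 3, where the six-membered ring was exchanged for the four-membered one and the number rose by a 4.1-fold higher number from compound 1 to compound 3 (0.61 log units; beyond the scatter). The change from compound 3 to compound 4 goes partway back toward compound 1. The other steps, a 6.4-fold higher number from compound 1 to compound 2 (0.81 log units; beyond the scatter) and a 1.6-fold lower number from compound 2 to compound 3 (0.20 log units; within the scatter), involve a different ring and speak less to this exchange.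

For compound 4 a lower number than compound 3 is therefore expected in this assay, and the estimate is 35 nM, with a range from 12 nM to 100 nM. This expected step, a 2.1-fold lower number from compound 3 to compound 4 (0.32 log units; beyond the scatter), would be modest.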

Compound 4, half-maximal inhibitory concentration: 105 nM
Beside the measured number, compound 4's estimate is 3.0-fold (0.48 log units) below it; measured number above the stated range.
By their numbers in this assay, from the lowest: compound 1; then compounds 3, 4 and 2 (each within the scatter of the next).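

Replacing 1-acetylazetidin-3-yl with 1-acetylpyrrolidin-3-yl on the amide-type nitrogen gives a 1.4-fold higher number from compound 3 to compound 4 (0.16 log units; within the scatter) in this assay, so this larger ring brings no measurable return toward the lower number of compound 1. The gap to the 1-acetylpiperidin-4-yl group stays wide, with a 5.8-fold higher number from compound 1 to compound 4 (0.77 log units; beyond the scatter), which means that among these three acetylated rings the number does not fall step by step as the ring grows: compound 1 stands alone, while compounds 3 and 4 cannot be told apart. The step of a 1.1-fold lower number from compound 2 to compound 4 (0.04 log units; within the scatter) adds that the 1-acetylpyrrolidin-3-yl and 1-methyl-6-oxopiperidin-3-yl groups also cannot be separated here, so compound 1 is the only one of the four with a clearly lower number.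

Nothing available here explains why compound 1 stands apart. Compound 1 differs from compound 4 in both ring size and attachment point, as the names 4-yl and 3-yl show, so a 1-acetylpiperidin-3-yl group would help separate those two changes, and a piperidin-4-yl group with a free amine would test whether the acetyl group matters.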